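Iodo to methoxy: what growth inhibition to expect

A few compounds are considered here, and "the series" means these few. Any claim that something is new, unique, unknown or untested is made for them only; others in the source may bear on it.

Compound 1 `NC(=O)c1cc(Cl)ccc1NC(=O)COc1ccccc1` gives 4900 nM
Compound 2 `NC(=O)c1cc(I)ccc1NC(=O)COc1ccccc1` gives 692 nM

In a functional assay on NCI60 cells (Homo sapiens) for inhibition (on this read-out higher numbers stand for weaker inhibition of growth and lower numbers for stronger inhibition of growth), compound 2 gives the lower number of the pair, at 692 nM against the value of compound 1 shown above. The next compound, compound 3 `COc1ccc(NC(=O)COc2ccccc2)c(C(N)=O)c1`, keeps the shared core and changes one group: methoxy in place of iodo on an aromatic carbon. In words, methoxy stands in place of iodo on an aromatic carbon, meta to a carbamoyl group and para to a large group.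

Among the measured compounds shown here, only one measured step bears on this carbon. It is a 7.1-fold lower number from compound 1 to compound 2 (0.85 log units; beyond the scatter), and it lies beyond the scatter, so a swap here can clearly move the number. For the measured compounds named here, no methoxy compound has been measured, which leaves the size of the new step uncertain. Going by the values given here, compound 2 holds the lowest value so far, and the one other group tried here gave a higher number, so a rise is the more likely direction. The expected change is a 4.3-fold higher number from compound 2 to compound 3 (0.64 log units; beyond the scatter), similar in size to the measured step. For compound 3 the estimated value is 3000 nM in this assay, with an expected range from 900 nM to 10000 nM here.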

Compound 3, concentration for 50% growth inhibition: 891 nM
The estimate for compound 3 lay 3.4-fold (0.53 log units) above the measured number; measured number outside the range, below it.
By their numbers in this assay, from the lowest: compounds 2 and 3 (each within the scatter of the next); then compound 1.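

In this assay the change from iodo to methoxy gives a 1.3-fold higher number from compound 2 to compound 3 (0.11 log units; within the scatter) and so leaves no readable difference between the two compounds, even though the groups differ in their atoms: iodo is one iodine atom with no hydrogen-bond acceptor, while methoxy has a carbon and an oxygen and counts one acceptor. The same methoxy group gives a 5.5-fold lower number from compound 1 to compound 3 (0.74 log units; beyond the scatter) and so stands clearly apart from chloro, which means that the drop in the number seen with iodo is no longer tied to iodine alone. Among the three groups tried on this carbon, two unlike groups now give numbers within the scatter of each other and chloro alone stands apart, though three compounds are too few to make this a rule for the position.

Going by these compounds, whether an amine, a carboxylic acid, a fluoro group or a longer chain such as ethoxy would stay with compound 2 and compound 3 or move towards compound 1 remains open. Nothing measured here explains why iodo and methoxy land so close together or why chloro differs from both.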